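This account rests on a few compounds, and the source may have more. Where it says the series, first, only, none or still open, it means among the compounds named here.

Compound 1 `COc1cc2c(/C=C3/C(=O)Nc4ccc(Cl)cc43)c(Cl)n(Cc3cc(OC)c(OC)c(OC)c3)c2cc1C` and compound 2 `COc1ccc2c(c1)/C(=C\c1c(Cl)n(Cc3cc(OC)c(OC)c(OC)c3)c3cc(C)c(OC)cc13)C(=O)N2` share one core and differ in a single group: methoxy in place of chloro on an aromatic carbon. In a functional assay on cells (Leukemia cell, Homo sapiens) for cytotoxicity, with a stated time of 48 h (a lower number here means a stronger inhibitor of growth, a higher number a weaker inhibitor of growth), compound 1 gives 4790 nM, and compound 2 gives 77600 nM; that change brought a 16-fold higher number from compound 1 to compound 2 (1.21 log units; beyond the scatter). Compound 3 `COc1c(/C=C2/C(=O)Nc3ccc(Cl)cc32)c2ccccc2n1-c1ccccc1` is built on another core; the difference between the two cores is not broken down here. In this assay compound 3 gives 8910 nM, a number that lies within the usual scatter of the number for compound 1 but stands well apart from the number for compound 2. Compound 4 `COc1ccc2c(c1)/C(=C\c1c(OC)n(-c3ccccc3)c3ccccc13)C(=O)N2` has not yet been measured. It differs from compound 3 by the same change, at the same place, that separates compound 1 from compound 2: methoxy in place of chloro on an aromatic carbon. Among the compounds with values here, for compound 4 a step of like size is expected, an estimated 11-fold higher number from compound 3 to compound 4 (1.05 log units; beyond the scatter), because the same change once gave a 16-fold higher number from compound 1 to compound 2 (1.21 log units; beyond the scatter), though with only one such pair in hand the guess is loosely held. Compound 4 is therefore expected to give about 100000 nM, most plausibly somewhere between 30000 nM and 300000 nM.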

Compound 4, concentration for total growth inhibition: 4470 nM
Compound 4: the middle estimate sits 22-fold (1.35 log units) above what was measured; measured number outside the range, below it.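

In this assay, methoxy in place of chloro on an aromatic carbon gives a 2.0-fold lower number from compound 3 to compound 4 (0.30 log units; within the scatter), so on this core the swap leaves the number within the usual scatter. Set beside the earlier pair, the same change does not carry over from one core to the other in this series: the same change on two cores in this assay, a 16-fold higher number (1.21 log units; beyond the scatter) from compound 1 to compound 2 and a 2.0-fold lower number (0.30 log units; within the scatter) from compound 3 to compound 4, 32-fold (1.51 log units) apart, beyond the scatter of two such steps. This shows that the large step seen on the core of compound 1 cannot be assumed on the core of compound 3, but it does not show which difference between the two cores matters, and two pairs give no rule for any third core.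

The compounds shown leave open which of the two results a further core would follow. They also leave open how an amine or a carboxylic acid would compare with chloro and methoxy on that same aromatic carbon, on either core.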